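Bromo for methoxy on the benzamide: cytotoxicity notes

The compounds below may be only part of what the source reports. "The series", "measured", "known", "first", "only" and "open" are said of these compounds alone.

Measured compounds in an ADME assay on HEK293 cells (Homo sapiens) for cytotoxicity, read by MTT assay, with a stated time of 72 h; a lower number here means a stronger inhibitor, a higher number a weaker inhibitor:
compound 1 `COc1cccc(C(=O)N2CCN(CC(=O)N3CCN(CCCc4c[nH]c5ccccc45)CC3)CC2)c1` gives 143000 nM.
compound 2 `O=C(CN1CCN(C(=O)c2cccc(Br)c2)CC1)N1CCN(CCCc2c[nH]c3ccccc23)CC1` gives 80700 nM.
compound 3 `COc1cccc(C(=O)N2CCN(CC(=O)N3CCN(CCCc4c[nH]c5ccc(OC)cc45)CC3)CC2)c1` gives > 200000 nM, which is a limit of the assay and not a number.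

The change bromo in place of methoxy on an aromatic carbon produced a 1.8-fold lower number from compound 1 to compound 2 (0.25 log units; within the scatter). Compound 4 `COc1ccc2[nH]cc(CCCN3CCN(C(=O)CN4CCN(C(=O)c5cccc(Br)c5)CC4)CC3)c2c1` carries the same change, (bromo in place of methoxy on an aromatic carbon), on the core of compound 3; that core differs from the core of compound 1 by methoxy in place of hydrogen on an aromatic carbon, a change that gave an at least 1.3-fold higher number from compound 1 to compound 3 (0.14 log units; that floor lies within the scatter). Compound 3 sits at the limit of > 200000 nM in this assay, at which 1 of the 3 values shown sits, so compound 4 may also come back as a limit. The expectation rests on compound 1 and compound 2, whose step was a 1.8-fold lower number from compound 1 to compound 2 (0.25 log units; within the scatter). For compound 4 the estimate is 200000 nM, between 90000 nM and 450000 nM. The expected step is a number no higher from compound 3 to compound 4 (the limit leaves the size open).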

Compound 4, half-maximal inhibitory concentration: 57000 nM
Compound 4: middle estimate off by 3.5-fold (0.55 log units), on the high side; the measured number lies below the stated range.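

In this assay, 3-methoxyphenyl to 3-bromophenyl on the methoxy-bearing core gives an at least 3.5-fold lower number from compound 3 to compound 4 (0.54 log units; beyond the scatter), so a step beyond the scatter appears on this core, while whether its size matches the step on the core of compound 1 cannot be settled: the same change on two cores in this assay, a 1.8-fold lower number (0.25 log units; within the scatter) from compound 1 to compound 2 and an at least 3.5-fold lower number (0.54 log units; beyond the scatter) from compound 3 to compound 4; the limit leaves it open whether they differ
The floor of that step rests on compound 3, whose value is a limit of the assay and not a number: the limit of > 200000 nM in this assay, at which 1 of the 4 values shown sits.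
With bromo in place, methoxy in place of hydrogen on an aromatic carbon gives a 1.4-fold lower number from compound 2 to compound 4 (0.15 log units; within the scatter), so this pair shows no clear effect of the core difference, and the comparison with the other core stays open: the same change on two cores in this assay, an at least 1.3-fold higher number (0.14 log units; that floor lies within the scatter) from compound 1 to compound 3 and a 1.4-fold lower number (0.15 log units; within the scatter) from compound 2 to compound 4; the limit leaves it open whether they differ

The compounds shown leave open whether an amine or a carboxylic acid in place of the bromo would follow the same course. They also leave open whether a third core would repeat the step.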